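Changing the Group on the Ring Nitrogen

This account rests on a few compounds, and the source may have more. Where it says the series, first, only, none or still open, it means among the compounds named here.

Of the compounds shown here, three have been measured in a functional assay on CHO-K1 cells for antagonist activity at prostaglandin E2 receptor EP3 subtype (Homo sapiens), read by TR-FRET and cAMP accumulation, with a stated time of 30 min; a lower number here means a stronger inhibitor, a higher number a weaker inhibitor. Compound 1 `COc1ccc(Cl)cc1S(=O)(=O)NC(=O)NC/C=C1\CCCc2cnn(Cc3ccc(Cl)cc3Cl)c21` gives 8 nM, and compound 2 `COc1ccc(S(=O)(=O)NC(=O)NC/C=C2\CCCc3cnn(Cc4ccc(Cl)cc4Cl)c32)cc1` gives 29 nM; the one-place step a 3.6-fold higher number from compound 1 to compound 2 (0.56 log units; beyond the scatter) concerns only the substituent on the sulfonyl sulfur. Compound 3 `O=C(NC/C=C1\CCCc2cnn(-c3ccc(C(F)(F)F)cc3)c21)NS(=O)(=O)c1cc(Cl)c(Cl)s1` gives 4 nM, the lowest of the three numbers: its gap to compound 1 lies within the scatter, whereas compound 2 sits beyond it.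

Compound 4 `O=C(NC/C=C1\CCCc2cnn(Cc3ccc(Cl)cc3Cl)c21)NS(=O)(=O)c1cc(Cl)c(Cl)s1` differs from compound 3 in one place: 2,4-dichlorobenzyl in place of 4-(trifluoromethyl)phenyl on an aromatic nitrogen. Going by the values given here, no measured step touches this position, so the measured step from compound 1 to compound 2 does not bear on it directly. Compounds 1 and 2 already carry the entering 2,4-dichlorobenzyl group, and compound 1 combines it with a different sulfonyl substituent while giving a number close to that of compound 3. For compound 4 the expected step is a 1.3-fold higher number from compound 3 to compound 4 (0.10 log units; within the scatter), that is, no change beyond the scatter. Compound 4 is therefore estimated to give about 5 nM in this assay, within the range 2 nM to 15 nM.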

Compound 4, half-maximal inhibitory concentration: 11 nM
For compound 4 the middle estimate is 2.2-fold (0.34 log units) below the measured one, within the range that was stated.
By their numbers in this assay, from the lowest: compounds 3, 1 and 4 (each within the scatter of the next, the first and the last beyond it); then compound 2.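

In this assay, the group on the aromatic nitrogen turns out to matter: with the 4,5-dichlorothiophen-2-yl group held fixed on the sulfonyl sulfur, the change to 2,4-dichlorobenzyl gives a 2.8-fold higher number from compound 3 to compound 4 (0.44 log units; beyond the scatter). With 2,4-dichlorobenzyl held fixed, the sulfonyl substituent can now be compared further: a 2.6-fold lower number from compound 2 to compound 4 (0.42 log units; beyond the scatter) favours 4,5-dichlorothiophen-2-yl over 4-methoxyphenyl, while a 1.4-fold higher number from compound 1 to compound 4 (0.14 log units; within the scatter) leaves it indistinguishable from 5-chloro-2-methoxyphenyl. Nothing available offers an explanation for the shift at the nitrogen.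

The compounds shown leave open how a methyl or an unsubstituted benzyl would read on this nitrogen. They also leave open whether the difference between these two nitrogen groups would persist with 4-methoxyphenyl or 5-chloro-2-methoxyphenyl on the sulfonyl sulfur.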